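Losing the iodine: what the shared core of compound 1 predicts

The source may report more compounds than this note shows. Statements on the series, on what has been measured and on what is new or still open speak of the compounds shown alone.

Compound 1 `CCCCNc1nc(N)nc(C)c1I` gives the lowest number of the three measured in an assay on HEK293 cells for agonist activity at Toll-like receptor 8 (Homo sapiens), read by reporter gene assay (on this read-out higher numbers stand for an effect only at larger amounts of compound and lower numbers for an effect already at smaller amounts), at 1640 nM. Compound 2 `CCCCCNc1nc(N)nc(C)c1I` gives 3700 nM, a modest step of a 2.3-fold higher number from compound 1 to compound 2 (0.35 log units; beyond the scatter). Compound 3 `CCCCNc1nc(N)nc(C)c1F` gives 34000 nM, a large step of a 21-fold higher number from compound 1 to compound 3 (1.32 log units; beyond the scatter). Compound 4 `CCCCNc1cc(C)nc(N)n1` differs from compound 1 by hydrogen in place of iodo on an aromatic carbon. Within the data shown here, only the step from compound 1 to compound 3 bears on this change, since both remove the iodo group from the same aromatic carbon; that step was large and toward higher numbers, and a step of comparable size in the same direction is expected here. Compound 4 is therefore estimated at 25000 nM, in a range from 8000 nM to 80000 nM. This estimate means an expected step of a 15-fold higher number from compound 1 to compound 4 (1.18 log units; beyond the scatter).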

Compound 4, half-maximal effective concentration: 22000 nM
Compound 4: the middle estimate sits 1.1-fold (0.06 log units) above what was measured; low and high end bracket the measured number.
By their numbers in this assay, from the lowest: compound 1; then compound 2; then compounds 4 and 3 (each within the scatter of the next).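

In this assay, hydrogen in place of iodo gives a 13-fold higher number from compound 1 to compound 4 (1.13 log units; beyond the scatter), so the large change seen with fluoro is not particular to fluoro. Hydrogen and fluoro on this aromatic carbon cannot be told apart, with a 1.5-fold lower number from compound 3 to compound 4 (0.19 log units; within the scatter) between them. Of these three groups on the core of compound 1, only iodo gives the lower number.

No measured evidence accompanies this result to explain it. On these data alone, whether bromo, chloro or a methyl group on this carbon would give a number nearer that of iodo or nearer those of hydrogen and fluoro stays open.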